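Swapping Fluoro for Chloro in Compound 3

The compounds below may be only part of what the source reports. "The series", "measured", "known", "first", "only" and "open" are said of these compounds alone.

Of the compounds shown here, two sharing one core have been measured in a functional assay on SiHa cells (Homo sapiens) for inhibition, read by MTT assay, with a stated time of 48 h; on this read-out lower numbers stand for stronger inhibition and higher numbers for weaker inhibition. Compound 1 `O=C(Nc1nc2ccc([N+](=O)[O-])cc2s1)c1cccnc1Nc1cc(F)c(F)c(F)c1` gives 36000 nM in this assay. Compound 2 `O=C(Nc1nc2ccc([N+](=O)[O-])cc2s1)c1cccnc1Nc1ccc(F)cc1` gives 7000 nM in this assay. Going by the values given here, the only measured step is a 5.1-fold lower number from compound 1 to compound 2 (0.71 log units; beyond the scatter), and after it compound 2 holds the lower of the two numbers. Compound 3 `O=C(Nc1nc2ccc([N+](=O)[O-])cc2s1)c1cccnc1Nc1ccc(Cl)cc1` has not yet been measured. It differs from compound 2 by chloro in place of fluoro on an aromatic carbon. Among the compounds with values here, the measured step, a 5.1-fold lower number from compound 1 to compound 2 (0.71 log units; beyond the scatter), changes how many fluorines sit on that ring and does not exchange one halogen for another, so it bears on the change to compound 3 only loosely; no measured step here replaces a fluoro with a chloro. On that footing, the exchange of a single fluoro for a single chloro is expected to move the number in this assay little, if at all, beyond the scatter. For compound 3 the expected value in this assay is 7000 nM, within a range of 2500 nM to 20000 nM. The step this estimate implies is no change at the digits printed from compound 2 to compound 3 (within the scatter).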

Compound 3, half-maximal inhibitory concentration: > 50000 nM
Compound 3: a limit, no number; the forecaster's own chance of this, stated with the estimate: 5%; at least 7.1-fold (0.85 log units) between middle value and limit.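

Compound 3 stands in this assay as a limit and not as a number: the limit of > 50000 nM in this assay, at which 1 of the 3 values shown sits. Even so, the exchange of one halogen atom on an aromatic carbon, para to a large group, is not a silent one, for the change from 4-fluorophenyl to 4-chlorophenyl gives an at least 7.1-fold higher number from compound 2 to compound 3 (0.85 log units; beyond the scatter) and so shows that this single position can move the number on its own, which the earlier change in the count of fluorines could not show. Set against the 3,4,5-trifluorophenyl group, the 4-chlorophenyl group gives an at least 1.3-fold higher number from compound 1 to compound 3 (0.14 log units; that floor lies within the scatter) and this floor does not put the two compounds in any order, so 4-fluorophenyl remains the only one of the three groups with a step beyond the scatter to both others.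

From the compounds shown here alone, how far compound 3 truly lies from compound 2 stays unknown, since its entry is a limit. Also open, going by these compounds, is whether a hydrogen, a methyl, a methoxy or a bromo at this same place would read like fluoro or like chloro, and whether chloro at another carbon of the ring would cost as much.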